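Boronate chalcone series: aryl changes on the carbonyl carbon

A few compounds are considered here, and "the series" means these few. Any claim that something is new, unique, unknown or untested is made for them only; others in the source may bear on it.

Three compounds of a shared core carry different aryl groups on the carbonyl carbon. Compound 1 `O=C(/C=C/c1ccc2c(c1)B(O)OC2)c1cccnc1` bears pyridin-3-yl and in a functional assay on HCT-116 cells (Homo sapiens) for cytotoxicity, read by MTT assay, with a stated time of 48 h (a higher number here means a weaker inhibitor, a lower number a stronger inhibitor), compound 1 gives 20500 nM. Compound 2 `CCc1ccc(C(=O)/C=C/c2ccc3c(c2)B(O)OC3)cc1` gives 10900 nM. Compound 3 `O=C(/C=C/c1ccc2c(c1)B(O)OC2)c1ccc(O)cc1` gives 24100 nM. Within these three numbers compound 1 stands second highest, nearest to compound 3 and furthest from compound 2, yet both gaps lie within the scatter.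

Two measured steps are known. a 1.2-fold higher number from compound 1 to compound 3 (0.07 log units; within the scatter) shows that swapping the aryl group on the carbonyl carbon leaves the number essentially unchanged. a 2.2-fold higher number from compound 2 to compound 3 (0.34 log units; beyond the scatter) shows a modest change from altering a substituent on the aromatic carbon.

The unmeasured compound 4 `O=C(/C=C/c1ccc2c(c1)B(O)OC2)c1cccc(F)c1` differs from compound 1 by 3-fluorophenyl in place of pyridin-3-yl on a carbonyl carbon. This step shares its place with the step from compound 1 to compound 3, which was within the scatter, and the whole series spans only a narrow range in this assay. A step of similar, small size is therefore expected in this assay, if anything towards a lower number, as compound 2, with a carbon-only ring carrying a substituent, gives 10900 nM.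

Compound 4 is expected at 15000 nM, within a range of 7000 nM to 35000 nM, the expected step being a 1.4-fold lower number from compound 1 to compound 4 (0.14 log units; within the scatter).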

Compound 4, half-maximal inhibitory concentration: 6700 nM
Beside the measured number, compound 4's estimate is 2.2-fold (0.35 log units) above it; the whole stated range lies above it.
By their numbers in this assay, from the lowest: compounds 4, 2, 1 and 3 (each within the scatter of the next, the first and the last beyond it).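

In this assay, the aryl group on the carbonyl carbon is not a silent place: 3-fluorophenyl in place of pyridin-3-yl gives a 3.1-fold lower number from compound 1 to compound 4 (0.49 log units; beyond the scatter), and 3-fluorophenyl in place of 4-hydroxyphenyl gives a 3.6-fold lower number from compound 3 to compound 4 (0.56 log units; beyond the scatter), both modest but beyond the scatter, so the flat reading from a 1.2-fold higher number from compound 1 to compound 3 (0.07 log units; within the scatter) holds for that pair only. Losing the ring nitrogen is not enough by itself to account for the new steps, as compound 3 also carries a carbon-only ring and stays within the scatter of compound 1. No supporting data bear on why the 3-fluorophenyl group gives the lower number.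

On these data alone, it remains open whether the fluorine counts at all, or whether any similar group would do; plain phenyl, 3-chlorophenyl or 3-methoxyphenyl on the carbonyl carbon would separate these readings. As far as these compounds go, it is also open how this place responds to an amine or a carboxylic acid on the ring, and whether these steps carry over to any other cell line.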